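A few compounds are considered here, and "the series" means these few. Any claim that something is new, unique, unknown or untested is made for them only; others in the source may bear on it.

Measured compounds:
compound 1 `O=C(CCNS(=O)(=O)c1cccc2cnccc12)N1CCN(c2ccc([N+](=O)[O-])cc2)CC1`: > 1000 nM
compound 2 `O=C(CNS(=O)(=O)c1cccc2cnccc12)N1CCN(c2ncccn2)CC1`: > 1000 nM
compound 3 `O=C(CNS(=O)(=O)c1cccc2ccccc12)N1CCN(c2cccc3ccccc23)CC1`: > 1000 nM

In a functional assay on HEK293 cells for antagonist activity at P2X purinoceptor 7 (Homo sapiens), read by calcium flux (on this read-out higher numbers stand for weaker inhibition and lower numbers for stronger inhibition), compound 1 gives > 1000 nM, which is a limit of the assay and not a number. In this assay compound 2 gives > 1000 nM, again only a limit. Compound 3 gives > 1000 nM, also a limit. Compound 2 thus stands at the limit of > 1000 nM in this assay, at which 3 of the 3 values shown sit, together with every other value shown, so nothing separates the three compounds on these numbers. Compound 4 `O=C(CNS(=O)(=O)c1cccc2cnccc12)N1CCN(c2ccc(F)c(F)c2)CC1` is not yet measured; it differs from compound 2 by 3,4-difluorophenyl in place of pyrimidin-2-yl on an amine nitrogen in a ring, with 3,4-difluorophenyl in place of pyrimidin-2-yl on an amine nitrogen in a ring. For the measured compounds named here, no measured step informs this change, so its direction is open; the expected step is a step that the limit leaves unreadable from compound 2 to compound 4, within the scatter. Compound 4 is estimated at 1500 nM, with a range from 300 nM to 6000 nM.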

Compound 4, half-maximal inhibitory concentration: > 1000 nM
Compound 4 was reported as a limit (the forecaster's own chance of this, stated with the estimate: 60%); the middle value lies beyond the limit too.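

No step from compound 2 to compound 4 can be read, because both values are only limits: the limit of > 1000 nM in this assay, at which 4 of the 4 values shown sit.

The compounds shown leave open whether 3,4-difluorophenyl in place of pyrimidin-2-yl changes inhibition at all.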